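Swapping the aryl group on the amide nitrogen

The source may report more compounds than this note shows. Statements on the series, on what has been measured and on what is new or still open speak of the compounds shown alone.

Compound 2 (`O=C(CSc1nc(Nc2ccccc2)c2ccccc2n1)Nc1cccc(Br)c1`) is one of three close relatives tested in a functional assay on NCI-H1975 cells (Homo sapiens) for inhibition, read by MTT assay, with a stated time of 72 h (on this read-out higher numbers stand for weaker inhibition and lower numbers for stronger inhibition), where compound 2 gives 10100 nM. That is the second highest of the three numbers. Its nearest neighbour is compound 1 (`O=C(CSc1nc(Nc2ccccc2)c2ccccc2n1)Nc1ccccc1F`), which gives 9350 nM, so the step of a 1.1-fold higher number from compound 1 to compound 2 (0.03 log units; within the scatter). Compound 3 (`O=C(CSc1nc(Nc2ccccc2)c2ccccc2n1)Nc1ccc(F)cc1`) gives 16500 nM, and the step of a 1.6-fold higher number from compound 2 to compound 3 (0.21 log units; within the scatter). The third comparison, a 1.8-fold higher number from compound 1 to compound 3 (0.25 log units; within the scatter), is likewise within the scatter. In other words, all three measured compounds sit in the same band, and none can be called stronger or weaker than another.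

Compound 4 (`O=C(CSc1nc(Nc2ccccc2)c2ccccc2n1)Nc1ccc(Cl)cc1Cl`) is the next step from compound 2. The change is 2,4-dichlorophenyl in place of 3-bromophenyl on an amide-type nitrogen. For the measured compounds named here, nothing measured so far introduces a 2,4-dichlorophenyl group, so there is no direct precedent. What the data do show is that each measured step swaps the phenyl group on the amide-type nitrogen for a differently substituted one, and every such swap stays within the scatter. On that basis the expected step of a 1.0-fold higher number from compound 2 to compound 4 (0.02 log units; within the scatter) is none beyond the scatter. Compound 4 is therefore estimated at 10500 nM, with a likely range from 4500 nM to 25000 nM.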

Compound 4, half-maximal inhibitory concentration: 8410 nM
Compound 4: middle estimate off by 1.2-fold (0.10 log units), on the high side; low and high end bracket the measured number.
By their numbers in this assay, from the lowest: compounds 4, 1, 2 and 3 (each within the scatter of the next).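

For the compounds shown here, the 2,4-dichlorophenyl group carries two chlorine atoms on its ring, whereas the earlier compounds each carry a single halogen, yet in this assay the added substitution moves nothing beyond the scatter, as the steps show: a 1.2-fold lower number from compound 2 to compound 4 (0.08 log units; within the scatter) and a 1.1-fold lower number from compound 1 to compound 4 (0.05 log units; within the scatter) and a 2.0-fold lower number from compound 3 to compound 4 (0.29 log units; within the scatter) in turn. Going by these compounds alone, the position on the amide-type nitrogen has now held fluorine, bromine and two chlorines, and no compound among the four can be ranked above another. Nothing beyond this one read-out bears on the result, so it offers no explanation for this flat picture.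

From the compounds shown here alone, all four compounds keep a halogen-bearing phenyl on the amide-type nitrogen, so it remains open whether a methoxy group, an amine or a carboxylic acid on that ring, or a longer chain in place of the ring, would shift the number beyond the scatter. The shared core also stays the same throughout, which leaves the effect of any change there unknown.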